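Swapping a Cyclopentyl for a Fluorinated Alkoxy Group

The source may report more compounds than this note shows. Statements on the series, on what has been measured and on what is new or still open speak of the compounds shown alone.

Of the compounds shown here, three have so far been measured in an assay on CHO-K1 cells for displacement of a labelled ligand from prostaglandin E2 receptor EP1 subtype (Homo sapiens); on this read-out higher numbers stand for weaker inhibition and lower numbers for stronger inhibition. Compound 1 `Cc1cc(C(=O)NN2CCOCC2)nn1Cc1cc(Cl)ccc1OCC(C)C` gives 251 nM. Compound 2 `Cc1cc(NC(=O)C2CCCC2)nn1Cc1cc(Cl)ccc1OCc1ccccc1` gives 15.9 nM. Compound 3 `Cc1cc(NC(=O)C2CCCC2)nn1Cc1cc(Cl)ccc1OCC(C)C` gives 25.1 nM, the second highest of the three numbers; it lies close to compound 2, while compound 1 is the furthest away. Of the two single-point steps already seen, a 10-fold lower number from compound 1 to compound 3 (1.00 log units; beyond the scatter) and a 1.6-fold higher number from compound 2 to compound 3 (0.20 log units; within the scatter) describe what happens when one arm or the other of the shared core is altered.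

Compound 4 `Cc1cc(NC(=O)OC(C)(C)C(F)(F)F)nn1Cc1cc(Cl)ccc1OCC(C)C` has not yet been measured. It differs from compound 3 in one place: 1-methyl-1-(trifluoromethyl)ethoxy in place of cyclopentyl on a carbonyl carbon. Among the compounds with values here, neither measured step touches this group directly, so the data give no close precedent. Still, because of a 10-fold lower number from compound 1 to compound 3 (1.00 log units; beyond the scatter) it is clear that changes at the carbonyl-bearing arm can move this assay well beyond the scatter, whereas a 1.6-fold higher number from compound 2 to compound 3 (0.20 log units; within the scatter) shows that a change on the ether arm stayed within it. A shift of real size is therefore expected, and in the absence of any guidance on direction a modest weakening is estimated. The expected step is a 2.0-fold higher number from compound 3 to compound 4 (0.30 log units; within the scatter). Compound 4 is thus estimated at 50 nM, within a range from 12 nM to 250 nM.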

Compound 4, half-maximal inhibitory concentration: 50.1 nM
For compound 4 the middle estimate is 1.0-fold (0.00 log units) below the measured one; low and high end bracket the measured number.
By their numbers in this assay, from the lowest: compounds 2, 3 and 4 (each within the scatter of the next, the first and the last beyond it); then compound 1.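

In this assay, putting 1-methyl-1-(trifluoromethyl)ethoxy in place of cyclopentyl on the carbonyl carbon gives a 2.0-fold higher number from compound 3 to compound 4 (0.30 log units; within the scatter), so this read-out does not tell the two groups apart. The exchange is a large one on paper: a five-membered ring of carbon only leaves, and an open group holding oxygen and fluorine enters, yet the carbonyl carbon and its amide-type nitrogen stay in place and the result remains within the scatter. This position can therefore take two very different groups without a step beyond the scatter, though that rests on this single pair, and the data offer no measured property that would explain it.

A tert-butoxy group on the same carbonyl carbon would show whether the three fluorine atoms count for anything here, and a plain ethoxy or a cyclohexyl would show how far the group can be varied in either direction. On these data alone, it also stays open whether the new group behaves the same way when the isobutyl on the ether oxygen gives way to the benzyl of compound 2.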